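A Trifluoromethyl for a Nitro in a Silent Series

The source may hold more compounds than are shown below. What is called first, only, known or untested is meant among the compounds shown, and "the series" means these compounds.

Compound 2 `O=[N+]([O-])c1ccc(NC(CO)CO)c([N+](=O)[O-])c1` stands at the edge of what was measured: in a functional assay on MDA-MB-231 cells (Homo sapiens) for cytotoxicity (a lower number here means a stronger inhibitor, a higher number a weaker inhibitor), compound 2 gives > 100000 nM, which is a limit of the assay and not a number. Compound 1 `O=[N+]([O-])c1ccccc1NC(CO)CO` likewise gives > 100000 nM, a limit. Compound 3 `O=[N+]([O-])c1cc(C(F)(F)F)ccc1NC(CO)CO` gives > 100000 nM, again a limit. Because all three sit at the limit of > 100000 nM in this assay, at which 3 of the 3 values shown sit, the steps a step that the two limits leave unreadable from compound 1 to compound 2, a step that the two limits leave unreadable from compound 1 to compound 3 and a step that the two limits leave unreadable from compound 2 to compound 3 cannot be read. Compound 4 `O=[N+]([O-])c1ccc(NC(CO)CO)c(C(F)(F)F)c1` differs from compound 2 by trifluoromethyl in place of nitro on an aromatic carbon. For the measured compounds named here, the only measured step of the same kind, a step that the two limits leave unreadable from compound 2 to compound 3, offers no size, so no direction beyond the scatter can be expected. Compound 4 is expected to stay at the limit, an estimated step that the limit leaves unreadable from compound 2 to compound 4. The estimate for compound 4 in this assay is 150000 nM, between 50000 nM and 500000 nM.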

Compound 4, half-maximal inhibitory concentration: > 100000 nM
Compound 4 ended at the assay's limit; the forecaster's own chance of this, stated with the estimate: 85%; the middle value is on the limit's open side.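

In this assay compound 4 gives > 100000 nM, a limit and not a number. For the compounds shown here, no step from compound 2 to compound 4 can be read. The compounds shown leave open whether trifluoromethyl in place of nitro changes cytotoxicity at all.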